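The source may report more compounds than this note shows. Statements on the series, on what has been measured and on what is new or still open speak of the compounds shown alone.

Compound 1 `C/C(=N\OC(=O)Nc1ccccc1)c1ccc(-c2ccccc2)cc1` gives 760 nM in an assay for inhibition of Fatty-acid amide hydrolase 1 (Mus musculus), read by scintillation counting; a lower number here means a stronger inhibitor, a higher number a weaker inhibitor.
Compound 2 `C/C(=N\OC(=O)Nc1ccccc1)c1cccc(-c2ccccc2)c1` gives 69 nM in this assay.

Of these two numbers, compound 2 has the lower one, and the gap to compound 1 lies well beyond the usual scatter, so compound 2 is the stronger inhibitor of the pair. Compound 3 `C/C(=N\OC(=O)Nc1ccc(F)cc1)c1cccc(-c2ccccc2)c1` differs from compound 2 in one place: fluoro in place of hydrogen on an aromatic carbon. Going by the values given here, no measured pair shows this kind of change, so nothing in the data gives its size directly. A single fluorine added at the far end of the carbamate part is a small change, and the expectation is a step no larger than the scatter, in either direction. The step expected from compound 2 to compound 3 in this assay is a 1.3-fold lower number from compound 2 to compound 3 (0.10 log units; within the scatter). Compound 3 is therefore estimated at 55 nM, with a likely range from 20 nM to 160 nM.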

Compound 3, half-maximal inhibitory concentration: 17 nM
Compound 3: middle estimate off by 3.2-fold (0.51 log units), on the high side; measured number below the stated range.
By their numbers in this assay, from the lowest: compound 3; then compound 2; then compound 1.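

Replacing one hydrogen with fluoro on the anilino ring, para to a large group, gives a 4.1-fold lower number from compound 2 to compound 3 (0.61 log units; beyond the scatter) in this assay and so makes compound 3 the strongest inhibitor of the three. The earlier comparison said nothing about this end of the molecule, whereas this result shows that the ring responds to even a single added fluorine atom, by more than the usual scatter. Nothing in the data available here explains why the number falls.

On these data alone, whether this step is specific to fluoro remains open, since chloro, methyl or methoxy at the same place would be needed to tell, as would fluoro on the other carbons of that ring. It is also unknown whether 4-fluorophenyl would give a similar step on the core of compound 1.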